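Aryl ketone change from compound 2 to compound 3

The compounds below may be only part of what the source reports. "The series", "measured", "known", "first", "only" and "open" are said of these compounds alone.

Compound 1 `COc1cc(-c2nnc3n2NC(c2ccco2)C(C(=O)c2ccccc2C)S3)cc(OC)c1OC` carries a methyl on the ring of the aryl ketone and in a functional assay on HepG2 cells (Homo sapiens) for cytotoxicity, read by MTT assay, with a stated time of 48 h (on this read-out higher numbers stand for weaker inhibition and lower numbers for stronger inhibition), compound 1 gives 63000 nM. Compound 2 `COc1cc(-c2nnc3n2NC(c2ccco2)C(C(=O)c2ccccc2F)S3)cc(OC)c1OC` differs by fluoro in place of methyl on an aromatic carbon. In this assay compound 2 reaches only the limit of the assay, > 100000 nM, and no number is known for it. The step reads an at least 1.5-fold higher number from compound 1 to compound 2 (0.20 log units; that floor lies within the scatter). Compound 2 thus stands at the limit of > 100000 nM in this assay, at which 1 of the 2 values shown sits. Compound 3 `COc1cc(-c2nnc3n2NC(c2ccco2)C(C(=O)c2ccc(Br)cc2)S3)cc(OC)c1OC` carries the change (4-bromophenyl in place of 2-fluorophenyl on a carbonyl carbon). Among the compounds with values here, only the step from compound 1 to compound 2 bears on it, a change of ring substituent on the same aryl ketone, and that step was small and capped by the limit. In this assay compound 3 is therefore expected to show a number no higher from compound 2 to compound 3 (the limit leaves the size open), nothing beyond the scatter. The estimate for compound 3 is 100000 nM, within 40000 nM to 250000 nM, with a fair chance of another limit.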

Compound 3, half-maximal inhibitory concentration: > 100000 nM
Compound 3 was reported as a limit; the forecaster's own chance of this, stated with the estimate: 50%; the middle value sits exactly at the limit.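

In this assay compound 3 gives > 100000 nM, a limit of the assay and not a number, so the step from compound 2 to compound 3 cannot be read. With 4-bromophenyl in place of 2-methylphenyl on the carbonyl carbon, the record shows an at least 1.5-fold higher number from compound 1 to compound 3 (0.20 log units; that floor lies within the scatter), a floor within the scatter, so this change says no more about size than the fluoro change did. Compound 1 remains the only one of the three with a number, and the values now gather at one end of the range: the limit of > 100000 nM in this assay, at which 2 of the 3 values shown sit.

Going by these compounds, the true values of compound 2 and compound 3 stay open, and with them any order between the 2-fluorophenyl and the 4-bromophenyl. Also open, on these data alone, is whether an amine or a carboxylic acid on this aryl ring, or a longer alkyl chain in place of the ring, would give a number within the range of this assay.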